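Benzyl at the Chain End: From Compound 2 to Compound 4

The source may hold more compounds than are shown below. What is called first, only, known or untested is meant among the compounds shown, and "the series" means these compounds.

Compound 1 `CCCCNc1nc(N)nc(C)c1CCCn1c(C)nc2ccccc21`: 366 nM
Compound 2 `CCCCNc1nc(N)nc(C)c1CC`: 1660 nM
Compound 3 `CCCCNc1nc(N)nc(C)c1CCCN1Cc2ccccc2C1`: 29 nM

Of the compounds shown here, three sharing one core have been measured in an assay on HEK293 cells for agonist activity at Toll-like receptor 8 (Homo sapiens), read by spectrophotometry; a lower number here means that less compound is needed, a higher number that more compound is needed for the effect. Compound 3 gives 29 nM, compound 1 gives 366 nM, and compound 2 gives 1660 nM. Compound 2 therefore stands at the top of the measured numbers: its nearest neighbour is compound 1, and compound 3 lies furthest from it, both differences being beyond the usual scatter. Compound 1 and compound 3 each carry a larger group at the end of the chain on the core, whereas compound 2 carries only a short alkyl chain there.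

Compound 4 `CCCCNc1nc(N)nc(C)c1CCCc1ccccc1` has not yet been measured in this assay. It differs from compound 2 in one place: benzyl in place of hydrogen on a saturated chain carbon, two bonds along the chain from an aromatic carbon. This brings compound 4 closer in shape to compound 1 and compound 3, though the group it adds is smaller and plainer than theirs.

Since both measured compounds with an extended chain end give lower numbers than compound 2, compound 4 is expected to follow in the same direction, with a step of a 6.6-fold lower number from compound 2 to compound 4 (0.82 log units; beyond the scatter) in this assay. For compound 4 the value in this assay is estimated at 250 nM, within a range from 70 nM to 900 nM.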

Compound 4, half-maximal effective concentration: 749 nM
The estimate for compound 4 lay 3.0-fold (0.48 log units) below the measured number, and the stated range covers the measured number.
By their numbers in this assay, from the lowest: compound 3; then compound 1; then compound 4; then compound 2.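

In this assay, among the compounds shown here, benzyl in place of hydrogen on a saturated chain carbon, two bonds along the chain from an aromatic carbon, gives the first step that can be read at a single place: a 2.2-fold lower number from compound 2 to compound 4 (0.35 log units; beyond the scatter), a modest change but one beyond the scatter. It shows that this position can take a plain ring of carbon only, with no hydrogen-bond donors or acceptors, and that the number still falls, something compound 1 and compound 3 could not show, as each differs from compound 2 in more than one place. Nothing measured here explains the size of this step.

The compounds shown leave open whether an amine at this same chain carbon, a longer chain carrying the phenyl ring, or a fluorine or methoxy group on the ring of the benzyl would move the number further in either direction. Steps linking compound 1 or compound 3 to the other compounds cannot be read, so what separates their values from that of compound 4 also remains open.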